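The compounds below may be only part of what the source reports. "The series", "measured", "known", "first", "only" and "open" are said of these compounds alone.

Measured compounds in an ADME assay on Vero cells (Chlorocebus sabaeus) for cytotoxicity, read by resazurin assay, with a stated time of 3 days; on this read-out lower numbers stand for stronger inhibition and higher numbers for weaker inhibition:

Compound 1, `CCN(CC)c1cc2[nH]c(C3CCCCC3)nc2cc1NC(=O)c1ccc(OC(F)(F)F)cc1`: reported only as the assay limit > 100 ug/mL.
Compound 2, `CCc1ccc(C(=O)Nc2cc3nc(C4CCCCC4)[nH]c3cc2N(C)C)cc1`: reported only as the assay limit > 100 ug/mL.
Compound 3, `CCOCCOC(=O)Nc1cc2nc(C3CCCCC3)[nH]c2cc1N(CC)CC`: reported only as the assay limit > 100 ug/mL.

Compound 3 thus stands at the ceiling of this assay rather than at a number, and it does so together with every other value shown, as the limit of > 100 ug/mL in this assay, at which 3 of the 3 values shown sit, states. Among the compounds with values here, the only step between measured compounds, a step that the two limits leave unreadable from compound 1 to compound 3, cannot be read in size or direction, because both ends of it are limits. Within the data shown here, there is consequently no measured step that gives a usable size for the change now considered.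

Compound 4, `CCc1ccc(C(=O)Nc2cc3nc(C4CCCCC4)[nH]c3cc2N(CC)CC)cc1`, differs from compound 3 by 4-ethylphenyl in place of 2-ethoxyethoxy on a carbonyl carbon. Compound 2, which also bears the (4-ethylphenyl)carbonyl group, is itself reported only as a limit in this assay. Among the measured compounds shown here, with all three measured values sitting at the limit and the one measured step unreadable, no step beyond the scatter is expected from compound 3 to compound 4 in this assay; the expected step is a step that the limit leaves unreadable from compound 3 to compound 4. Compound 4 is therefore estimated at 150 ug/mL in this assay, within a range from 60 ug/mL to 400 ug/mL, and most likely to be reported again only as a limit.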

Compound 4, half-maximal inhibitory concentration: > 100 ug/mL
Compound 4 was reported as a limit (the forecaster's own chance of this, stated with the estimate: 85%); the middle value is on the limit's open side.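

In this assay compound 4 gives > 100 ug/mL, which is a limit of the assay. None of the steps to compound 4 from compound 1, compound 2 or compound 3 can be read, because both ends of each are limits: the limit of > 100 ug/mL in this assay, at which 4 of the 4 values shown sit.

The compounds shown leave open whether any of these changes has an effect on cytotoxicity that this assay can size, and how the four compounds rank.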